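A Longer Amino Chain in Place of Diethylamino

The source may hold more compounds than are shown below. What is called first, only, known or untested is meant among the compounds shown, and "the series" means these compounds.

In a functional assay on the whole organism for positive allosteric modulation, with Mus musculus as the target (on this read-out lower numbers stand for an effect already at smaller amounts and higher numbers for an effect only at larger amounts of compound), compound 1 `CCC(=O)N(c1ccc(Cl)cc1)C1CCCC1N(C)C` reaches only a limit of the assay, > 50 mg/kg and no number. For the measured compounds named here, compound 2 `CCC(=O)N(c1ccc(Cl)c(Cl)c1)C1CCCC1N(CC)CC` gives 0.3 mg/kg as the only actual number so far, so it has no measured neighbour to be ranked against. Going by the values given here, compound 3 `CCC(=O)N(c1ccc(Cl)c(Cl)c1)C1CCCC1N(C)CCCN(C)C` keeps the rest of compound 2 and carries (3-(dimethylamino)propyl)(methyl)amino in place of diethylamino on a saturated ring carbon as its single change. Among the compounds with values here, no measured step bears on this exchange, so the expectation is a judgement from the structural change alone. In this assay a shift well beyond the usual scatter towards larger doses is expected, and the estimated size is a 27-fold higher number from compound 2 to compound 3 (1.43 log units; beyond the scatter) for this exchange. For compound 3 the expected value is 8 mg/kg with 1 mg/kg to 50 mg/kg as the estimated range.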

Compound 3, dose for half-maximal effect: 30 mg/kg
Compound 3: the middle estimate sits 3.8-fold (0.57 log units) below what was measured; measured number inside the range.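

In this assay, the amino group on a saturated ring carbon proves sensitive to exchange: with the rest of the molecule held, (3-(dimethylamino)propyl)(methyl)amino in place of diethylamino gives a 100-fold higher number from compound 2 to compound 3 (2.00 log units; beyond the scatter). For the compounds shown here, this is the first measured step, and it shows that the larger group with its second nitrogen goes with a need for a much larger dose, although compound 3 still returns a number. Compound 1 stands at a limit of the assay rather than at a number, and further steps in this direction could end at that limit too: the limit of > 50 mg/kg in this assay, at which 1 of the 3 values shown sits.

On these data alone, a single step cannot separate the added chain from the second amine, so the outcome with a plain dipropylamino group or a ring amine such as pyrrolidine stays open. Going by these compounds alone, whether the exchange would run alike with the single chlorine of compound 1 also stays open.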